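Adding a Methyl to the Chain: Compound 4 Expected

A few compounds are considered here, and "the series" means these few. Any claim that something is new, unique, unknown or untested is made for them only; others in the source may bear on it.

Compound 1 `CC(C)c1ccc(NC(=O)N[C@H](C)c2ccccc2)cc1` gives 49% in an ADME assay on the whole organism with Oryza sativa as the target, tested at 10 uM; on this read-out higher numbers stand for a weaker effect at the one concentration tested and lower numbers for a stronger effect; compound 2 `C[C@@H](NC(=O)Nc1ccc(C(C)(C)C)cc1)c1ccccc1` gives 53%; compound 3 `CCCCCCc1ccc(NC(=O)N[C@H](C)c2ccccc2)cc1` gives 101%.

Compound 2 differs from compound 1 by methyl in place of hydrogen on a saturated chain carbon bound to an aromatic carbon and two saturated chain carbons, a step of a number 4 percentage points higher from compound 1 to compound 2 (within the scatter). Compound 4 `CCCCCCCc1ccc(NC(=O)N[C@H](C)c2ccccc2)cc1` differs from compound 3 by methyl in place of hydrogen on a saturated chain carbon, six bonds along the chain from an aromatic carbon. This is the same kind of change, but the place is not the same: in compound 1 the carbon is bound to an aromatic carbon and two saturated chain carbons, while in compound 3 it lies six bonds along the chain from an aromatic carbon. The cores also differ: hexyl in place of isopropyl on an aromatic carbon, which carried a step of a number 52 percentage points higher from compound 1 to compound 3 (beyond the scatter).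

For compound 4 a step of about no change at the digits printed from compound 3 to compound 4 (within the scatter) is expected, because the earlier methyl step gave a number 4 percentage points higher from compound 1 to compound 2 (within the scatter). Compound 4 is therefore estimated at 101%, between 88% and 112%.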

Compound 4, a percentage reported as activity, at one concentration (the size of the read-out at that concentration, not a potency): 100%
For compound 4 the middle estimate is 1 percentage points above the measured one; low and high end bracket the measured number.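

In this assay, the methyl that turns hexyl into heptyl gives a step of a number 1 percentage points lower from compound 3 to compound 4 (within the scatter), and the same change reads alike on the two cores: the same change on two cores in this assay, a number 4 percentage points higher (within the scatter) from compound 1 to compound 2 and a number 1 percentage points lower (within the scatter) from compound 3 to compound 4, 5 percentage points apart, within the scatter of two such steps This shows that the change made no step beyond the scatter at these two carbons, but it does not show the same for other carbons or other cores in this series. Heptyl stays well apart from the shorter groups, with steps of a number 47 percentage points higher from compound 2 to compound 4 (beyond the scatter) and a number 51 percentage points higher from compound 1 to compound 4 (beyond the scatter), and these steps do not explain why.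

The compounds shown leave open how a butyl or pentyl chain would read, and so where along the chain lengths the large step arises. They also leave open how an amine or a carboxylic acid in place of the chain would read.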